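Trifluoromethoxy for Trifluoromethyl: Expected Tolerance of Compound 4

The source may hold more compounds than are shown below. What is called first, only, known or untested is meant among the compounds shown, and "the series" means these compounds.

Compound 1 `CN1CCN(CCCNCc2cn(-c3ccc(C(F)(F)F)cc3)nc2-c2ccc(OC(F)(F)F)cc2)CC1`: 2300 nM
Compound 2 `CCCN1CCC(CNCc2cn(-c3ccc(C(F)(F)F)cc3)nc2-c2ccc(C(F)(F)F)cc2)CC1`: 1200 nM
Compound 3 `CN1CCN(CCNCc2cn(-c3ccc(C(F)(F)F)cc3)nc2-c2ccc(C(F)(F)F)cc2)CC1`: 1500 nM

All three were measured in an ADME assay on Huh-7 cells (Homo sapiens) for cytotoxicity; a higher number here means that more compound is tolerated, a lower number that less compound is tolerated. Among them compound 2 gives the lowest number, 1200 nM, yet it is not set apart: the step of a 1.3-fold higher number from compound 2 to compound 3 (0.10 log units; within the scatter) stays within the scatter, and compound 1 sits only a little further off at 2300 nM, also within the scatter of compound 2. Compound 3 gives 1500 nM.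

Compound 4 `CCCN1CCC(CNCc2cn(-c3ccc(C(F)(F)F)cc3)nc2-c2ccc(OC(F)(F)F)cc2)CC1` differs from compound 2 in one place: trifluoromethoxy in place of trifluoromethyl on an aromatic carbon. Among the compounds with values here, no measured pair isolates exactly this change. Compound 1 and compound 3 differ by this same swap together with a second change in the chain, and their numbers lie within the scatter of each other. Within the data shown here, the only single-point step available, a 1.3-fold higher number from compound 2 to compound 3 (0.10 log units; within the scatter), concerns a different part of the molecule and is itself within the scatter.

On this basis the step of a 1.3-fold higher number from compound 2 to compound 4 (0.10 log units; within the scatter) is expected to be small, with no direction that rises above the scatter. Compound 4 is therefore estimated at 1500 nM, within 700 nM to 3500 nM.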

Compound 4, half-maximal cytotoxic concentration: 2200 nM
Estimate against measurement, compound 4: 1.5-fold (0.17 log units) below; the range from low to high includes it.
By their numbers in this assay, from the lowest: compounds 2, 3, 4 and 1 (each within the scatter of the next).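

In this assay the swap of trifluoromethyl for trifluoromethoxy on an aromatic carbon, para to a large group, can now be read on its own: it gives a 1.8-fold higher number from compound 2 to compound 4 (0.26 log units; within the scatter) and so, in this one pair, has no effect that can be told from the scatter. Within the data shown here, with trifluoromethoxy held fixed, the side chain can also be compared for the first time, and 1-propylpiperidin-4-yl in place of 2-(4-methylpiperazin-1-yl)ethyl gives a 1.0-fold lower number from compound 1 to compound 4 (0.02 log units; within the scatter) in this assay as well, so neither the aromatic swap nor this chain change separates the compounds. Nothing available here offers an explanation for how closely these numbers agree.

On these data alone, both groups compared at this position carry three fluorines, so it remains open whether a quite different group there, such as a nitrile, a carboxylic acid or an amine, would give a step beyond the scatter. As far as these compounds go, on the other side of the molecule, it is equally open whether a longer chain on the piperidine nitrogen, in place of propyl, would move the number in this assay by more than these small steps.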